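The source may report more compounds than this note shows. Statements on the series, on what has been measured and on what is new or still open speak of the compounds shown alone.

In a functional assay on B16 cells (Mus musculus) for antiproliferative activity, read by MTT assay, with a stated time of 24 h (a lower number here means a stronger inhibitor, a higher number a weaker inhibitor), two compounds have been measured so far:

Compound 1 `COc1cc(OC)c(-c2coc3cc(OCc4ccccc4C#N)ccc3c2=O)cc1OC`: 2140 nM
Compound 2 `COc1cc(OC)c(-c2coc3cc(OCc4ccccc4Cl)ccc3c2=O)cc1OC`: 4180 nM

Compound 2 stands level with compound 1, as their two values lie within the scatter of each other. Compound 3 `COc1cc(OC)c(-c2coc3cc(OCc4cccc(C(F)(F)F)c4)ccc3c2=O)cc1OC` has not yet been measured in this assay and differs from compound 2 by one change: 3-(trifluoromethyl)phenyl in place of 2-chlorophenyl on a saturated chain carbon bound to an oxygen on an aromatic ring on a saturated chain carbon bound to an oxygen on an aromatic ring. Neither measured compound carries trifluoromethyl. For the measured compounds named here, only one measured step bears on this change, a 2.0-fold higher number from compound 1 to compound 2 (0.29 log units; within the scatter) for chloro in place of cyano on an aromatic carbon, so no step beyond the scatter is expected in either direction. The estimated step is a 1.2-fold lower number from compound 2 to compound 3 (0.08 log units; within the scatter) and is expected to stay within the scatter. Compound 3 is expected at 3500 nM with an estimated range from 1300 nM to 9000 nM.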

Compound 3, half-maximal inhibitory concentration: > 10000 nM
Compound 3 gave a limit, no number; the forecaster's own chance of this, stated with the estimate: 5%; middle value at least 2.8-fold (0.45 log units) away from the limit.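

In this assay compound 3 gives a limit of the assay, not a number: the limit of > 10000 nM in this assay, at which 1 of the 3 values shown sits. Even so, the change from 2-chlorobenzyl to 3-(trifluoromethyl)benzyl can be read as an at least 2.3-fold higher number from compound 2 to compound 3 (0.37 log units; beyond the scatter), and the change from the cyano-bearing benzyl as an at least 4.6-fold higher number from compound 1 to compound 3 (0.66 log units; beyond the scatter). The earlier step between chloro and cyano stayed within the scatter, whereas changes on the saturated chain carbon bound to an oxygen on an aromatic ring now move the number beyond it, towards weaker inhibition.

The change to compound 3 swaps the group and its place on the ring in one move, so the compounds shown cannot tell which of the two carries the step. They also leave open how a benzyl group carrying an amine or a carboxylic acid would behave in this assay.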